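The source may hold more compounds than are shown below. What is called first, only, known or untested is meant among the compounds shown, and "the series" means these compounds.

Of the compounds shown here, three have so far been measured in a functional assay on SW-620 cells (Homo sapiens) for antiproliferative activity, read by MTT assay, with a stated time of 72 h; a lower number here means a stronger inhibitor, a higher number a weaker inhibitor. Compound 1 `CCCCCc1ccc(C#Cc2c(-c3ccc(CCCCC)cc3)oc3nc(=O)n(Cc4cn(-c5ccccc5F)nn4)cc23)cc1` gives 57100 nM in this assay. Compound 2 `CCCCCCC#Cc1c(CCCCCC)oc2nc(=O)n(Cc3cn(Cc4ccccc4)nn3)cc12` gives 32600 nM in this assay. For compound 3 `O=c1nc2oc(CCCCl)cc2cn1Cc1cn(-c2ccc(F)cc2)nn1` the read-out is not a number but a limit of the assay, > 100000 nM. Compound 3 thus stands at the limit of > 100000 nM in this assay, at which 1 of the 3 values shown sits. Compound 3 therefore has no number of its own to set beside the other two.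

Compound 4 `O=c1nc2oc(CCCCl)cc2cn1Cc1cn(-c2ccc(Cl)cc2)nn1` is the next compound to be measured. It differs from compound 3 in a single place: chloro in place of fluoro on an aromatic carbon. For the measured compounds named here, no pair of measured compounds differs in only one place, so no measured step exists to show how large an effect such an exchange has here. The expectation is that this exchange produces no step beyond the usual scatter, and that compound 4, like compound 3, will most likely return only a limit. The estimated step is a step that the limit leaves unreadable from compound 3 to compound 4, within the scatter. Compound 4 is expected to give about 150000 nM in this assay, with a range from 60000 nM to 400000 nM.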

Compound 4, half-maximal inhibitory concentration: > 100000 nM
Compound 4 ended at the assay's limit; the forecaster's own chance of this, stated with the estimate: 70%; the middle value lies beyond the limit too.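

Compound 3 and compound 4 both return only a limit in this assay, so no step between them can be read: the limit of > 100000 nM in this assay, at which 2 of the 4 values shown sit.

On these data alone, what remains open is how much chloro in place of fluoro on an aromatic carbon changes activity where the values are actual numbers.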